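Methoxy for methyl on the enone aryl of compound 3

A few compounds are considered here, and "the series" means these few. Any claim that something is new, unique, unknown or untested is made for them only; others in the source may bear on it.

Measured compounds:
compound 1 `COc1ccc(C(=O)/C=C/c2cc(-c3cc(OC)c(OC)c(OC)c3)n3nc(-c4ccccc4)cc3n2)cc1` — 25200 nM
compound 2 `COc1ccc(-c2cc(C(=O)/C=C/c3ccc(C)cc3)nc3cc(-c4ccccc4)nn23)cc1OC` — 19500 nM
compound 3 `COc1ccc(-c2cc(/C=C/C(=O)c3ccc(C)cc3)nc3cc(-c4ccccc4)nn23)cc1OC` — 26800 nM

In a functional assay on DU-145 cells (Homo sapiens) for antiproliferative activity, read by MTT assay, with a stated time of 24 h (a lower number here means a stronger inhibitor, a higher number a weaker inhibitor), compound 3 gives 26800 nM, the highest of the three numbers, though it sits within the scatter of both compound 1 and compound 2. Among the measured compounds shown here, the only single-point step among the measured compounds is a 1.4-fold higher number from compound 2 to compound 3 (0.14 log units; within the scatter), which reverses the enone and does not touch the substituent examined here.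

Compound 4 `COc1ccc(C(=O)/C=C/c2cc(-c3ccc(OC)c(OC)c3)n3nc(-c4ccccc4)cc3n2)cc1` differs from compound 3 by methoxy in place of methyl on an aromatic carbon. For the measured compounds named here, no measured step changes methyl into methoxy on this aryl ring, so nothing in the data speaks directly to it. Compound 1 carries the same methoxyphenyl carbonyl as compound 4 and differs from it only on the other aryl ring. In this assay compound 1 gives 25200 nM, essentially the same number as compound 3. The three measured values all lie within the scatter of one another, and the change from methyl to methoxy is small by count.

Compound 4 is therefore expected to stay close to compound 3, with an estimated step of a 1.2-fold lower number from compound 3 to compound 4 (0.07 log units; within the scatter). The estimate for compound 4 in this assay is 23000 nM, with a range from 9000 nM to 55000 nM.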

Compound 4, half-maximal inhibitory concentration: 14600 nM
Compound 4: the middle estimate sits 1.6-fold (0.20 log units) above what was measured; the measured number falls inside the stated range.
By their numbers in this assay, from the lowest: compounds 4, 2, 1 and 3 (each within the scatter of the next).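

In this assay, among the compounds shown here, the direct swap of methoxy for methyl on the aryl ring of the enone gives a 1.8-fold lower number from compound 3 to compound 4 (0.26 log units; within the scatter), so this position, read here for the first time, accepts the change without leaving the scatter. The two other new steps read the same way: one methoxy comes off the other aryl ring in a 1.7-fold lower number from compound 1 to compound 4 (0.24 log units; within the scatter), and the direction of the enone changes along with the same swap in a 1.3-fold lower number from compound 2 to compound 4 (0.13 log units; within the scatter), so neither change separates these compounds in this assay. No measurement on hand accounts for these numbers, and the small differences among them are left without an explanation.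

With all the steps shown within the scatter, it remains open whether any group on this ring can move the number beyond it, for example a hydroxyl, a dimethylamino group or a longer alkoxy chain such as butoxy in place of the methoxy. Also open, going by these compounds, is whether the other aryl ring, which so far carries only methoxy groups, would respond to an amine or a carboxylic acid.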